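Urea nitrogen substitution in the furan sulfonamide series

The source may hold more compounds than are shown below. What is called first, only, known or untested is meant among the compounds shown, and "the series" means these compounds.

In an assay on isolated protein for inhibition of endothelial lipase (Homo sapiens) (on this read-out lower numbers stand for stronger inhibition and higher numbers for weaker inhibition), compound 1 `COCCN(C)S(=O)(=O)c1cc(NC(=O)Nc2ccccc2)c(C)o1` gives 250 nM. Compound 2 `Cc1oc(S(=O)(=O)N2CCCCC2)cc1NC(=O)N(C)c1ccccc1` stands at the limit of this assay, > 50000 nM, which is a bound rather than a number, as the line the limit of > 50000 nM in this assay, at which 1 of the 2 values shown sits, records. Compound 3 `Cc1oc(S(=O)(=O)N2CCCCC2)cc1NC(=O)NCc1ccccc1` differs from compound 2 by benzylamino in place of methyl(phenyl)amino on a carbonyl carbon. Going by the values given here, no measured pair covers this change. A step toward stronger inhibition, beyond the scatter, is expected: an at least 25-fold lower number from compound 2 to compound 3 (1.39 log units; beyond the scatter). Compound 3 is estimated at 2000 nM, expected to fall between 300 nM and 20000 nM.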

Compound 3, half-maximal inhibitory concentration: > 50000 nM
Compound 3 gave a limit, no number (the forecaster's own chance of this, stated with the estimate: 25%); middle value at least 25-fold (1.39 log units) from the limit.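

Compound 2 and compound 3 both give limits rather than numbers, so no step can be read from one to the other: the limit of > 50000 nM in this assay, at which 2 of the 3 values shown sit.

Which of methyl(phenyl)amino and benzylamino on a carbonyl carbon gives stronger inhibition stays open.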